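A Pyridyl Ring Replaces a Difluorophenyl Ring

The compounds below may be only part of what the source reports. "The series", "measured", "known", "first", "only" and "open" are said of these compounds alone.

Compound 2 `O=C(O)Cc1sc(C(c2ccc(F)cc2)c2ccc(F)cc2)nc1-c1cc(F)cc(F)c1` gives 80% in an in vitro functional assay on HEK285-7 cells for antagonist activity at prostaglandin D2 receptor 2 (Homo sapiens), read by BRET and beta-arrestin recruitment (a lower number here means a smaller maximal response, a higher number a larger maximal response), level with compound 1 `NS(=O)(=O)c1ccc(-c2nc(C(c3ccc(F)cc3)c3ccc(F)cc3)sc2CC(=O)O)cc1`, which gives 80%. Within the data shown here, the one step measured so far, no change at the digits printed from compound 1 to compound 2 (within the scatter), exchanged one six-membered aromatic ring for another at the same place on the shared core and left the maximal response unchanged within the scatter.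

Compound 3 `O=C(O)Cc1sc(C(c2ccc(F)cc2)c2ccc(F)cc2)nc1-c1ccncc1` differs from compound 2 by pyridin-4-yl in place of 3,5-difluorophenyl on an aromatic carbon. This is again a swap of one six-membered aromatic ring for another at the same place on the shared core. Among the measured compounds shown here, the only step that bears on it is no change at the digits printed from compound 1 to compound 2 (within the scatter), which showed no change beyond the scatter; no measured step involves a pyridin-4-yl group, so the effect of a ring nitrogen here is untested. On that basis, no change beyond the scatter is expected, and the estimated step is no change at the digits printed from compound 2 to compound 3 (within the scatter). Compound 3 is therefore estimated at 80%, with an expected range from 68% to 92%.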

Compound 3, largest response reached (reported as efficacy), in percent of the reference or control that the assay uses: 80%
Estimate against measurement, compound 3: no gap at the digits printed; the measured number falls inside the stated range.
By their numbers in this assay, from the lowest: compounds 1, 2 and 3 (each within the scatter of the next).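

Among these compounds, the first measured step to bring a ring nitrogen to this aromatic carbon, pyridin-4-yl in place of 3,5-difluorophenyl, gives in this assay no change at the digits printed from compound 2 to compound 3 (within the scatter). Pyridin-4-yl in place of 4-sulfamoylphenyl gives no change at the digits printed from compound 1 to compound 3 (within the scatter), so at this place a ring with a hetero atom now reads the same as two carbon-only rings with quite different substituents. Nothing measured here explains this lack of difference.

From the compounds shown here alone, all three groups are six-membered aromatic rings, so it remains open whether the maximal response would hold with a five-membered ring such as thienyl at this carbon. Going by these compounds, it is equally open what an amine or a plain methyl group would give there, with no aromatic ring attached at all.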